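The source may report more compounds than this note shows. Statements on the series, on what has been measured and on what is new or still open speak of the compounds shown alone.

Of the compounds shown here, two that share a core have been measured in a functional assay on HL-60 cells (Homo sapiens), with a stated time of 4 days; a lower number here means a stronger inhibitor, a higher number a weaker inhibitor. Compound 1 `O=C(Nc1ccc(Cl)c(Cl)c1)c1nc[nH]c1C(=O)NCc1ccc(Cl)cc1` gives 8800 nM in this assay. Compound 2 `C[C@@H](NC(=O)c1[nH]cnc1C(=O)Nc1ccc(Cl)c(Cl)c1)c1ccccc1` gives 5900 nM in this assay. Among the measured compounds shown here, the only step between measured compounds, a 1.5-fold lower number from compound 1 to compound 2 (0.17 log units; within the scatter), swaps one group for another on an amide-type nitrogen and lies within the scatter. On the numbers shown, compound 2 carries the lower of the two values, yet its nearest neighbour, compound 1, sits within the scatter of it, so no order between them can be claimed.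

Compound 3 `CCCN(CCC)C(=O)c1[nH]cnc1C(=O)Nc1ccc(Cl)c(Cl)c1` has not yet been measured. It differs from compound 2 by dipropylamino in place of (1-phenylethyl)amino on a carbonyl carbon. For the measured compounds named here, the single measured step, a 1.5-fold lower number from compound 1 to compound 2 (0.17 log units; within the scatter), kept a ring on that side of the molecule and was within the scatter; no measured step removes the ring and the hydrogen-bond donor as this change does, so the data bear only loosely on it. The number for compound 3 in this assay is therefore expected to stay close to that of compound 2, with an estimated step of a 2.0-fold higher number from compound 2 to compound 3 (0.31 log units; beyond the scatter). Compound 3 is estimated at 12000 nM, in a range from 4000 nM to 40000 nM.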

Compound 3, half-maximal inhibitory concentration: 38900 nM
Beside the measured number, compound 3's estimate is 3.2-fold (0.51 log units) below it; the measured number falls inside the stated range.
By their numbers in this assay, from the lowest: compounds 2 and 1 (each within the scatter of the next); then compound 3.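

Among the compounds shown here, replacing the ring-bearing group on this carbonyl carbon is the first change in this assay that lies beyond the scatter: dipropylamino gives a 6.6-fold higher number from compound 2 to compound 3 (0.82 log units; beyond the scatter) and, measured against the (4-chlorobenzyl)amino group, a 4.4-fold higher number from compound 1 to compound 3 (0.65 log units; beyond the scatter) in a step that is likewise modest. For the compounds shown here, the earlier pair showed only that two ring-bearing amino groups could not be told apart here, whereas compound 3 shows that the number does respond to what sits at this position, and that the open-chain dipropylamino group gives a weaker inhibitor than either of them. No measurement shown here accounts for this loss.

The change from (1-phenylethyl)amino to dipropylamino removes the six-membered aromatic ring, the hydrogen-bond donor and the defined stereocentre all at once, and the compounds shown do not separate these differences. Open questions remain for propylamino, which carries a chain and keeps the amide hydrogen, and for benzyl(methyl)amino, which keeps an aromatic ring but has no amide hydrogen; either group would change only part of what changed in compound 3.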